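Amide Substituent Swap on a Vitamin D Receptor Agonist Core

The source may hold more compounds than are shown below. What is called first, only, known or untested is meant among the compounds shown, and "the series" means these compounds.

Measured so far:
compound 1, `CCn1c(C(=O)NCC(OC)OC)ccc1C(CC)(CC)c1ccc(OCC(=O)C(C)(C)C)c(C)c1`: 130 nM
compound 2, `CCn1c(C(=O)NCCN)ccc1C(CC)(CC)c1ccc(OCC(=O)C(C)(C)C)c(C)c1`: 120 nM

Both were tested in an assay on HL-60 cells for agonist activity at vitamin D3 receptor (Homo sapiens), read by microscopy, with a stated time of 96 h; a higher number here means that more compound is needed for the effect, a lower number that less compound is needed. Compound 2 gives 120 nM, and compound 1 gives 130 nM; the step of a 1.1-fold lower number from compound 1 to compound 2 (0.03 log units; within the scatter) lies within the scatter, so the two stand level. Compound 3, `C=CCN(C)C(=O)c1ccc(C(CC)(CC)c2ccc(OCC(=O)C(C)(C)C)c(C)c2)n1CC`, differs from compound 2 by allyl(methyl)amino in place of (2-aminoethyl)amino on a carbonyl carbon. Among the compounds with values here, the only measured step concerns the same amide group and was within the scatter, so little movement is expected here either, perhaps a slightly higher number. Compound 3 is estimated at 200 nM (range 70 nM to 600 nM), a step of a 1.7-fold higher number from compound 2 to compound 3 (0.22 log units; within the scatter).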

Compound 3, half-maximal effective concentration: 21600 nM
Compound 3: the middle estimate sits 110-fold (2.03 log units) below what was measured; measured number above the stated range.
By their numbers in this assay, from the lowest: compounds 2 and 1 (each within the scatter of the next); then compound 3.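

This position is far less forgiving than the earlier pair suggested: allyl(methyl)amino in place of (2-aminoethyl)amino gives a 180-fold higher number from compound 2 to compound 3 (2.26 log units; beyond the scatter), and in place of (2,2-dimethoxyethyl)amino it gives a 170-fold higher number from compound 1 to compound 3 (2.22 log units; beyond the scatter). Compound 1 and compound 2 stand level despite their different chains, so the tolerance seen there does not extend to every amide substituent. No available evidence accounts for this jump.

Compound 3 keeps no amide hydrogen and also carries a methyl and an allyl group, so these changes remain unseparated. As far as these compounds go, whether a simple allylamino or methylamino group behaves like compound 2 or like compound 3 remains open.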